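Methoxy on the benzyl ring: one repeated change, two cores

This account rests on a few compounds, and the source may have more. Where it says the series, first, only, none or still open, it means among the compounds named here.

Measured so far in a functional assay on HepG2 cells (Homo sapiens) for antiproliferative activity, read by CCK-8 assay, with a stated time of 48 h; on this read-out lower numbers stand for stronger inhibition and higher numbers for weaker inhibition:
compound 1 `O=C(NCc1ccccc1)c1cc(Oc2ccc(/C=C/c3ccccn3)cc2)ccn1` gives 27900 nM;
compound 2 `COc1ccc(CNC(=O)c2cc(Oc3ccc(/C=C/c4ccccn4)cc3)ccn2)cc1` gives 26000 nM;
compound 3 `O=C(NCc1ccccc1)c1cc(Oc2ccc(/C=C/c3ccncc3)cc2)ccn1` gives 28900 nM.

All three numbers lie close together. From compound 1 to compound 2 the change is methoxy in place of hydrogen on an aromatic carbon, and it gives a 1.1-fold lower number from compound 1 to compound 2 (0.03 log units; within the scatter). Compound 3 differs from compound 1 in its core by pyridin-4-yl in place of pyridin-2-yl on a double-bonded chain carbon bound to a double-bonded chain carbon, a swap that gives a 1.0-fold higher number from compound 1 to compound 3 (0.02 log units; within the scatter).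

Compound 4 `COc1ccc(CNC(=O)c2cc(Oc3ccc(/C=C/c4ccncc4)cc3)ccn2)cc1` is not yet measured. It stands to compound 3 as compound 2 stands to compound 1: the change is methoxy in place of hydrogen on an aromatic carbon, the same change at the same place, made now on the core of compound 3. Because the earlier step of a 1.1-fold lower number from compound 1 to compound 2 (0.03 log units; within the scatter) stayed within the scatter, the expected step here is also small, a 1.1-fold lower number from compound 3 to compound 4 (0.03 log units; within the scatter). Compound 4 is therefore estimated at 27000 nM, with a likely range from 14000 nM to 52000 nM.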

Compound 4, half-maximal inhibitory concentration: > 100000 nM
Compound 4 was reported as a limit; the forecaster's own chance of this, stated with the estimate: 5%; middle value at least 3.7-fold (0.56 log units) from the limit.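

In this assay compound 4 is reported only as a limit, > 100000 nM. The methoxy change therefore does not carry over from the core of compound 1 to the core of compound 3, with an at least 3.4-fold higher number from compound 3 to compound 4 (0.53 log units; beyond the scatter) standing against the earlier step: the same change on two cores in this assay, a 1.1-fold lower number (0.03 log units; within the scatter) from compound 1 to compound 2 and an at least 3.4-fold higher number (0.53 log units; beyond the scatter) from compound 3 to compound 4, at least 3.7-fold (0.56 log units) apart, beyond the scatter of two such steps. The pyridin-4-yl swap also depends on its partner, with an at least 3.8-fold higher number from compound 2 to compound 4 (0.58 log units; beyond the scatter), but the limit leaves the true size of both steps unknown, and these numbers do not say why the two cores part: the same change on two cores in this assay, a 1.0-fold higher number (0.02 log units; within the scatter) from compound 1 to compound 3 and an at least 3.8-fold higher number (0.58 log units; beyond the scatter) from compound 2 to compound 4, at least 3.7-fold (0.56 log units) apart, beyond the scatter of two such steps.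

On these data alone, it remains open whether a different group at the same place on the benzyl ring, such as fluorine or hydroxy, would follow methoxy on the core of compound 3. A pyridin-3-yl core also stays untested among the compounds shown.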